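Nitro in place of amino on an aromatic carbon

The source may hold more compounds than are shown below. What is called first, only, known or untested is meant among the compounds shown, and "the series" means these compounds.

In a functional assay on K562 cells (Homo sapiens) for inhibition, read by trypan blue exclusion, with a stated time of 72 h (a higher number here means a weaker inhibitor, a lower number a stronger inhibitor), compound 1 `COc1ccc(S(=O)(=O)c2cc3cnc(Nc4ccc5[nH]ccc5c4)nc3n(C)c2=O)cc1` gives 300 nM, while compound 2 `Cn1c(=O)c(S(=O)(=O)c2ccc(N)cc2F)cc2cnc(Nc3ccc4[nH]ccc4c3)nc21` gives 1500 nM, the higher of the two numbers and so the weaker inhibitor of the pair. Going by the values given here, the only measured step is a 5.0-fold higher number from compound 1 to compound 2 (0.70 log units; beyond the scatter), with 4-amino-2-fluorophenyl in place of 4-methoxyphenyl on a sulfonyl sulfur. Compound 3 `Cn1c(=O)c(S(=O)(=O)c2ccc([N+](=O)[O-])cc2F)cc2cnc(Nc3ccc4[nH]ccc4c3)nc21` alters compound 2 in one place: nitro in place of amino on an aromatic carbon. This puts nitro in place of amino on an aromatic carbon, meta to a fluoro group and para to a large group, turning 4-amino-2-fluorophenyl into 2-fluoro-4-nitrophenyl. Among the compounds with values here, no measured pair isolates this exchange. Within the data shown here, the step to compound 2 at 1500 nM shows only that the group on the sulfonyl sulfur can move the number, and it gives no firm direction for nitro. A step no larger than that one is therefore expected, leaning weakly towards a lower number. The estimated step is a 1.5-fold lower number from compound 2 to compound 3 (0.18 log units; within the scatter). For compound 3 the expected value is 1000 nM, with an estimated range from 300 nM to 3500 nM.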

Compound 3, half-maximal inhibitory concentration: 200 nM
For compound 3 the middle estimate is 5.0-fold (0.70 log units) above the measured one; the measured number lies below the stated range.
By their numbers in this assay, from the lowest: compounds 3 and 1 (each within the scatter of the next); then compound 2.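

In this assay, going by these compounds alone, the exchange gives the first direct reading at the position para to the large group and meta to the fluoro group, with the fluoro group held constant: a 7.5-fold lower number from compound 2 to compound 3 (0.88 log units; beyond the scatter). Set against compound 1, the 2-fluoro-4-nitrophenyl group gives a 1.5-fold lower number from compound 1 to compound 3 (0.18 log units; within the scatter), whereas the 4-amino-2-fluorophenyl group gave a 5.0-fold higher number from compound 1 to compound 2 (0.70 log units; beyond the scatter), so among these three compounds carrying the fluoro group does not by itself go with a higher number. The data offer no independent measurement that would account for the size of the step from amino to nitro.

As far as these compounds go, whether amino is the unusual group at this position, or nitro is, remains open, and a nitrile, a carboxylic acid or a methoxy group at the same place on the 2-fluorophenyl ring would help to tell these apart. What the fluoro group itself contributes also remains open: no pair shown changes it alone, and a 4-nitrophenyl group carrying hydrogen in place of fluoro would isolate that single change.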